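A few compounds are considered here, and "the series" means these few. Any claim that something is new, unique, unknown or untested is made for them only; others in the source may bear on it.

Compound 1, `O=C(Nc1ccc(-n2ccc3c(NC(=O)c4ccccc4)nccc32)cc1)Nc1ccc(Cl)c(Cl)c1`: 11500 nM
Compound 2, `CCN1CCN(Cc2ccc(NC(=O)Nc3ccc(-n4ccc5c(NC(=O)c6ccccc6)nccc54)cc3)cc2C(F)(F)F)CC1`: 980 nM

Both compounds were tested in an ADME assay on NIH3T3 cells (Mus musculus) for antiproliferative activity, read by MTT assay, with a stated time of 48 h, in the presence of a further agent that is not named here; a lower number here means a stronger inhibitor, a higher number a weaker inhibitor. Of the two numbers, compound 1 gives the higher one, 11500 nM, while compound 2 gives 980 nM; the gap between them lies beyond the usual scatter, so compound 1 is the weaker inhibitor of the pair. The step followed here leads from compound 1 to compound 3, `O=C(Nc1ccc(-n2ccc3c(NC(=O)c4ccccc4)nccc32)cc1)c1cccc(C(F)(F)F)c1`, which has not yet been measured. The change is 3-(trifluoromethyl)phenyl in place of (3,4-dichlorophenyl)amino on a carbonyl carbon. In plain terms, the urea that links the shared core to the last ring becomes a simple amide, and that ring carries a trifluoromethyl in place of the chlorines. Among the compounds with values here, no measured pair differs in exactly this way, so there is no direct precedent. Compound 2 also carries a trifluoromethyl, but together with other changes, so its value cannot serve as a guide for this step alone. Compound 3 is expected to show a step of a 1.3-fold higher number from compound 1 to compound 3 (0.12 log units; within the scatter), a change that would stay within the usual scatter. Compound 3 is therefore estimated at 15000 nM, with a range from 4000 nM to 60000 nM.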

Compound 3, half-maximal inhibitory concentration: 50 nM
The estimate for compound 3 lay 300-fold (2.48 log units) above the measured number; the measured number lies below the stated range.
By their numbers in this assay, from the lowest: compound 3; then compound 2; then compound 1.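

In this assay, putting 3-(trifluoromethyl)phenyl in place of (3,4-dichlorophenyl)amino on the carbonyl carbon gives a 230-fold lower number from compound 1 to compound 3 (2.36 log units; beyond the scatter), a large step beyond the usual scatter. This position is therefore far from indifferent to what stands on that carbonyl carbon, and the simple amide in compound 3 can give a much stronger inhibitor than the urea in compound 1. The two earlier compounds both carry the urea link, so neither could show what happens when it is replaced. No measurement shown here bears on why the number falls so far.

On these data alone, the step also changes two things at once: the amino nitrogen with its hydrogen-bond donor leaves, and the chlorines give way to a trifluoromethyl, so the share of each remains open. An amide carrying 3,4-dichlorophenyl and a urea carrying 3-(trifluoromethyl)phenyl would pull these apart, and whether a nitrile or a methoxy group on that ring keeps the number this low is also unknown from these compounds.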